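The source may hold more compounds than are shown below. What is called first, only, known or untested is meant among the compounds shown, and "the series" means these compounds.

Compound 1 `O=C1c2cccc(O)c2C(=O)C1(O)O` in an assay on isolated protein for inhibition of carbonic anhydrase 4 (Homo sapiens), read by stopped-flow, with a stated time of 15 min (a higher number here means a weaker inhibitor, a lower number a stronger inhibitor), gives > 100000 nM, which is a limit of the assay and not a number.
Compound 2 `COc1cccc2c1C(=O)C(O)(O)C2=O` gives > 100000 nM, again a limit.
Compound 3 `Cc1cccc2c1C(=O)C(O)(O)C2=O` gives > 100000 nM, also a limit.

Compound 2 therefore stands at the limit of > 100000 nM in this assay, at which 3 of the 3 values shown sit, with no number of its own. The change to compound 4 `COc1ccc(OC)c2c1C(=O)C(O)(O)C2=O` is methoxy in place of hydrogen on an aromatic carbon. The measured steps that come closest are a step that the two limits leave unreadable from compound 1 to compound 2 and a step that the two limits leave unreadable from compound 2 to compound 3, both unreadable because each of their compounds sits at the limit of > 100000 nM in this assay, at which 3 of the 3 values shown sit. No readable step exists, so no direction can be expected beyond the scatter; the shared core shows no measurable inhibition in any of the three. Compound 4 is expected to give 200000 nM, within 50000 nM to 1000000 nM, most likely again a limit. The step from compound 2 to compound 4 is thus estimated at a step that the limit leaves unreadable from compound 2 to compound 4.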

Compound 4, inhibition constant: > 100000 nM
Compound 4: a limit, no number; the forecaster's own chance of this, stated with the estimate: 85%; the middle value does not contradict the limit.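

Compound 2 and compound 4 both give a limit of the assay and not a number, so no size can be read for the step between them: the limit of > 100000 nM in this assay, at which 4 of the 4 values shown sit.

The compounds shown leave open what change to the shared core, if any, would give a measurable inhibition constant in this assay.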